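The source may report more compounds than this note shows. Statements on the series, on what has been measured and on what is new or still open speak of the compounds shown alone.

Among the measured compounds shown here, compound 1, with the structure `O=C1O/C(=C\Cn2cc(Cc3ccccc3)nn2)C(OCc2ccccc2)=C1OCc1ccccc1`, is the only member of this small set for which a number is available: in a functional assay on MDA-MB-231 cells (Homo sapiens) for antiproliferative activity, read by MTT assay, with a stated time of 24 h (on this read-out lower numbers stand for stronger inhibition and higher numbers for weaker inhibition), compound 1 gives 29200 nM. Its companion, compound 2, with the structure `O=C1NC(O)(CCn2cc(Cc3ccccc3)nn2)C(OCc2ccccc2)=C1OCc1ccccc1`, does not provide a number in this assay; for compound 2 only the limit > 100000 nM is recorded, and that limit is the line (the limit of > 100000 nM in this assay, at which 1 of the 2 values shown sits). Compound 1 therefore stands as the sole fixed point against which anything new is judged.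

Compound 3, with the structure `O=C1O/C(=C\Cn2cc(C3=CCCCC3)nn2)C(OCc2ccccc2)=C1OCc1ccccc1`, differs from compound 1 in one place only: cyclohex-1-en-1-yl in place of benzyl on an aromatic carbon. For the measured compounds named here, no step between two measured compounds of this set touches that position, so the direction of the change cannot be read from a precedent. The expectation for compound 3 is that the step from compound 1 in this assay stays small, within or just beyond the usual scatter, and slightly toward weaker inhibition, as a 1.3-fold higher number from compound 1 to compound 3 (0.11 log units; within the scatter). Compound 3 is accordingly estimated at 38000 nM, with a plausible range from 12000 nM to 100000 nM in this assay.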

Compound 3, half-maximal inhibitory concentration: > 100000 nM
Compound 3 was reported as a limit (the forecaster's own chance of this, stated with the estimate: 25%); middle value at least 2.6-fold (0.42 log units) from the limit.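

In this assay, cyclohex-1-en-1-yl in place of benzyl on the aromatic carbon of the five-membered ring gives an at least 3.4-fold higher number from compound 1 to compound 3 (0.53 log units; beyond the scatter). Among the compounds shown here, this is the first step in the set that touches this position, and it shows that the read-out responds to the group placed there, even when one six-membered ring of carbon only is exchanged for another. The value of compound 3 is a limit and not a number, so the full size of the step stays unknown, and it is now one of two such values in this small set: the limit of > 100000 nM in this assay, at which 2 of the 3 values shown sit.

The compounds shown do not separate the two things that change together here, the loss of the aromatic ring and the loss of the carbon link that joins benzyl to the core, and a phenyl group or a cyclohexylmethyl group at this position would pull these apart. Going by these compounds, it also remains open whether a benzyl ring carrying an amine or a carboxylic acid would move the number from compound 1 in either direction.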